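Furan-3-yl in place of cyclohexyl on the triazole core

This account rests on a few compounds, and the source may have more. Where it says the series, first, only, none or still open, it means among the compounds named here.

Compound 1, `CCc1nc(C(=O)OC)nn1-c1ccc(F)cc1`: 11000 nM
Compound 2, `COC(=O)c1nc(C2CC2)n(-c2ccc(F)cc2)n1`: 9420 nM
Compound 3, `COC(=O)c1nc(C2CCCCC2)n(-c2ccc(F)cc2)n1`: > 100000 nM

In a functional assay on Jurkat cells (Homo sapiens) for inhibition, read by MTT assay, with a stated time of 72 h (a lower number here means a stronger inhibitor of growth, a higher number a weaker inhibitor of growth), compound 3 gives only a limit, > 100000 nM, and so stands at the weak end of the three measured compounds (the limit of > 100000 nM in this assay, at which 1 of the 3 values shown sits). Compound 4, `COC(=O)c1nc(-c2ccoc2)n(-c2ccc(F)cc2)n1`, differs from compound 3 in one place: furan-3-yl in place of cyclohexyl on an aromatic carbon. Among the measured compounds shown here, the steps that bear on this are an at least 9.0-fold higher number from compound 1 to compound 3 (0.95 log units; beyond the scatter) and an at least 10-fold higher number from compound 2 to compound 3 (1.02 log units; beyond the scatter), both of which show that replacing a small group by cyclohexyl weakens growth inhibition. Removing cyclohexyl again in favour of the smaller furan-3-yl is therefore expected to reverse part of that loss, giving a lower number an at least 5.0-fold lower number from compound 3 to compound 4 (0.69 log units; beyond the scatter). Compound 4 is estimated at 20000 nM in this assay, within a range of 5000 nM to 100000 nM.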

Compound 4, concentration for 50% growth inhibition: 9320 nM
Compound 4: the middle estimate sits 2.1-fold (0.33 log units) above what was measured; the measured number falls inside the stated range.
By their numbers in this assay, from the lowest: compounds 4, 2 and 1 (each within the scatter of the next). At a limit, above all of these: compound 3.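

In this assay, a ring at this position need not cost growth inhibition: furan-3-yl gives an at least 10-fold lower number from compound 3 to compound 4 (1.03 log units; beyond the scatter). Compound 3 gives only a limit, so this step is a bound: the limit of > 100000 nM in this assay, at which 1 of the 4 values shown sits. The other two steps, a 1.0-fold lower number from compound 2 to compound 4 (0.00 log units; within the scatter) and a 1.2-fold lower number from compound 1 to compound 4 (0.07 log units; within the scatter), lie within the scatter, so furan-3-yl, with its 5 heavy atoms, is tolerated here as well as ethyl or cyclopropyl.

From the compounds shown here alone, what remains open is whether the furan oxygen matters, which a phenyl or thiophene ring here could test. Going by these compounds, whether an amine at this carbon would lower the number also remains open.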